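Salicylanilide series: cytotoxicity notes toward compound 3

The source may hold more compounds than are shown below. What is called first, only, known or untested is meant among the compounds shown, and "the series" means these compounds.

The shared core of compound 1 `CC(=O)Nc1ccc(NC(=O)c2cc(Cl)ccc2O)c(Cl)c1` carries an acetylated nitrogen on the aniline ring; in an ADME assay on A549 cells (Homo sapiens) for cytotoxicity, read by resazurin assay, with a stated time of 48 h (on this read-out lower numbers stand for higher toxicity in this test and higher numbers for lower toxicity in this test), compound 1 gives "not determined" (no result reported), so no single number places it. Compound 2 `CC(C)Nc1ccc(NC(=O)c2cc(Cl)ccc2O)c(Cl)c1` is the closest neighbour with a result: in this assay compound 2 gives 11000 nM. Compound 3 `O=C(Nc1ccc(NCc2cc(Cl)cc(Cl)c2)cc1Cl)c1cc(Cl)ccc1O` differs from compound 1 by 3,5-dichlorobenzyl in place of acetyl on a nitrogen on an aromatic ring. Going by the values given here, with no measured step for this pair, the step in this assay is expected to be modest, toward somewhat higher toxicity than compound 2 shows, possibly beyond the scatter. Compound 3 is estimated at 5000 nM, within 1500 nM to 20000 nM.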

Compound 3, half-maximal cytotoxic concentration: 13300 nM
For compound 3 the middle estimate is 2.7-fold (0.42 log units) below the measured one, and the stated range covers the measured number.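

In this assay the step is a 1.2-fold higher number from compound 2 to compound 3 (0.08 log units; within the scatter) when 3,5-dichlorobenzyl takes the place of isopropyl on a nitrogen on an aromatic ring. Compound 2 and compound 3 thus stay within the scatter of each other, so at this position a group carrying a six-membered aromatic ring and chlorine reads the same as a small branched alkyl group.

From the compounds shown here alone, whether a carboxylic acid or a longer chain ending in an amine on this nitrogen would also read the same stays open. The data shown offer no explanation for this flat step.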